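A few compounds are considered here, and "the series" means these few. Any claim that something is new, unique, unknown or untested is made for them only; others in the source may bear on it.

Measured compounds in a functional assay on the whole organism (artery, strain albino) with Rattus norvegicus as the target, with a stated time of 15 min, at a dose of 10 mg/kg by the oral route; on this read-out lower numbers stand for less inhibition and higher numbers for more inhibition at the one dose given (going by the name of the read-out):

Compound 1 `CC1=C(C(=O)Nc2ccc(F)cc2)C(c2ccc([N+](=O)[O-])cc2)N=C(SCc2ccccc2)N1`: 3.1%
Compound 2 `CC1=C(C(=O)Nc2ccc(F)cc2)C(c2ccc([N+](=O)[O-])cc2)N=C(SCc2ccccc2Cl)N1`: 1.5%
Compound 3 `CC1=C(C(=O)Nc2ccc([N+](=O)[O-])cc2)C(c2ccc(Br)cc2)N=C(SCc2ccccc2)N1`: 2.1%

All three measured numbers lie close together, within the usual scatter of one another, so no ordering among them is claimed. Within the data shown here, the one step measured in one place is chloro in place of hydrogen on an aromatic carbon, which gives a number 1.6 percentage points lower from compound 1 to compound 2 (within the scatter). Compound 4 `CC1=C(C(=O)Nc2ccc([N+](=O)[O-])cc2)C(c2ccc(Br)cc2)N=C(SCc2ccccc2Cl)N1` is not yet measured. It arises from compound 3 by the same change, (chloro in place of hydrogen on an aromatic carbon), with the same surroundings at the place of change. The difference between the cores of compound 1 and compound 3 is not broken down here.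

Beside the step from compound 1 to compound 2, the corresponding step from compound 3 to compound 4 is expected to be about a number 0.6 percentage points lower from compound 3 to compound 4 (within the scatter), a size resting on a number 1.6 percentage points lower from compound 1 to compound 2 (within the scatter) and on the low starting number of compound 3 at 2.1%. Compound 4 is therefore estimated at 1.5%, with a likely range from -5% to 8%.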

Compound 4, a percentage reported as inhibition, in the whole organism at one dose (the size of the read-out at that dose, not a potency): 1.5%
The estimate for compound 4 equals the measured number at the digits printed; the measured number falls inside the stated range.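

In this assay the change from benzylsulfanyl to (2-chlorobenzyl)sulfanyl on the core of compound 3 gives a number 0.6 percentage points lower from compound 3 to compound 4 (within the scatter) and agrees with the earlier step: the same change on two cores in this assay, a number 1.6 percentage points lower (within the scatter) from compound 1 to compound 2 and a number 0.6 percentage points lower (within the scatter) from compound 3 to compound 4, 1 percentage points apart, within the scatter of two such steps. Both steps lie within the scatter, so the two cores show no readable difference in their response to this change. This does not show that the change carries a real effect from one core to another, and it does not show how the change would read on a core with a clearly larger inhibition.

Chloro is the only replacement for hydrogen shown on this ring. Going by these compounds, a methoxy group, a carboxylic acid or an amine at the same place remains open, as does any replacement of the whole benzylsulfanyl group.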